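Compound 3 gains a butylamino group

A few compounds are considered here, and "the series" means these few. Any claim that something is new, unique, unknown or untested is made for them only; others in the source may bear on it.

Measured in an ADME assay on HaCaT cells (Homo sapiens) for cytotoxicity, read by MTT assay, with a stated time of 72 h; on this read-out lower numbers stand for stronger inhibition and higher numbers for weaker inhibition:
Compound 1 `CCCCCCCCNC1=CC(=O)C=C(C[C@]2(C)[C@@H](C)CC[C@]3(C)C(C)=CCC[C@@H]23)C1=O`: 17000 nM
Compound 2 `CCCCNC1=CC(=O)C(C[C@]2(C)[C@@H](C)CC[C@]3(C)C(C)=CCC[C@@H]23)=CC1=O`: > 100000 nM
Compound 3 `CC1=CCC[C@H]2[C@](C)(CC3=CC(=O)C=CC3=O)[C@@H](C)CC[C@]12C`: 37000 nM

Only two of these results are actual numbers. Compound 3 holds the higher one, and its nearest neighbour is compound 1, with 17000 nM. Compound 2 gives > 100000 nM, which is a limit of the assay and not a number.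

The next compound is compound 4 `CCCCNC1=CC(=O)C=C(C[C@]2(C)[C@@H](C)CC[C@]3(C)C(C)=CCC[C@@H]23)C1=O`, which has butylamino in place of hydrogen on a double-bonded ring carbon of compound 3: butylamino in place of hydrogen on a double-bonded ring carbon. The new group stands two ring bonds from the ring atom that bears a large group. For the measured compounds named here, two measured steps bear on this change. Compound 1 has octylamino at that same place, and the step is a 2.2-fold higher number from compound 1 to compound 3 (0.34 log units; beyond the scatter). Compound 2 has the same butylamino group at another place on the ring, and the step is an at least 2.7-fold lower number from compound 2 to compound 3 (0.43 log units; beyond the scatter). The two steps run in opposite directions, so the amino compounds fall on both sides of compound 3. No clear step is therefore expected in this assay, although the uncertainty is wide.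

The estimated change is a 1.1-fold higher number from compound 3 to compound 4 (0.03 log units; within the scatter).

Compound 4 is estimated at 40000 nM, with an expected range from 15000 nM to 100000 nM.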

Compound 4, half-maximal inhibitory concentration: 16000 nM
Beside the measured number, compound 4's estimate is 2.5-fold (0.40 log units) above it; the range from low to high includes it.
By their numbers in this assay, from the lowest: compounds 4 and 1 (each within the scatter of the next); then compound 3. At a limit, above all of these: compound 2.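

In this assay, for the compounds shown here, butylamino at this place goes with a 2.3-fold lower number from compound 3 to compound 4 (0.36 log units; beyond the scatter) and so with a modest lowering of the number, which the earlier compounds could only suggest. Chain length shows no such effect here: the change from octylamino to butylamino gives a 1.1-fold lower number from compound 1 to compound 4 (0.03 log units; within the scatter) and stays within the scatter, so both amino compounds at this place sit on the same side of compound 3. The place on the ring also appears to matter, as compound 2 carries the same butylamino group at another place on the ring and its result is a limit of the assay, not a number: the limit of > 100000 nM in this assay, at which 1 of the 4 values shown sits.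

The compounds shown leave open whether a shorter chain such as methylamino, or a different group at this place such as hydroxyl or dimethylamino, would give the same lower number. From the compounds shown here alone, compound 2 gives no number, and how far its value lies from those of the other compounds remains unknown.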